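The compounds below may be only part of what the source reports. "The series", "measured", "known", "first", "only" and "open" are said of these compounds alone.

Compound 2 (`Clc1cc2nc(Br)n(Cc3ccccc3)c2cc1Cl`) stands at > 100000 nM in a functional assay on CEM-SS cells (Homo sapiens) for cytotoxicity (on this read-out lower numbers stand for stronger inhibition and higher numbers for weaker inhibition), which is a limit and not a number. Compound 3 (`Clc1ccc(Cn2c(Br)nc3cc(Cl)c(Cl)cc32)cc1`) differs from compound 2 by chloro in place of hydrogen on an aromatic carbon, para to a large group: chloro in place of hydrogen on an aromatic carbon. Among the measured compounds shown here, no measured step in this assay isolates this change. A modest move towards stronger inhibition is expected, resting only on compound 1 (`Nc1nc2cc(Cl)c(Cl)cc2n1Cc1ccc(Cl)cc1`), which bears the same chloro and gives 32000 nM. The expected change is an at least 2.0-fold lower number from compound 2 to compound 3 (0.30 log units; that floor lies within the scatter). For compound 3 the estimate is 50000 nM, with an expected range of 18000 nM to 100000 nM.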

Compound 3, half-maximal inhibitory concentration: > 100000 nM
Compound 3: no number, only a limit; the forecaster's own chance of this, stated with the estimate: 40%; middle value at least 2.0-fold (0.30 log units) away from the limit.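

In this assay compound 3 gives > 100000 nM as a limit and not a number. The chloro step at this position, para to a large group, cannot be read, and the value of compound 2 is also a limit: the limit of > 100000 nM in this assay, at which 2 of the 3 values shown sit. Bromo in place of amino on an aromatic carbon, with the chloro present in both compounds, gives an at least 3.1-fold higher number from compound 1 to compound 3 (0.49 log units; beyond the scatter) and is the only step here that can be read.

Open, from the compounds shown here alone, is the size of the chloro step on a core that reads as a number, such as the core of compound 1. Also open, going by these compounds, is how a methoxy group in the place of the chloro would read.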